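This account rests on a few compounds, and the source may have more. Where it says the series, first, only, none or still open, it means among the compounds named here.

Working notes on the series. The shared core carries a phenyl ring whose para substituent varies across the set. Compound 1 `c1ccc(-c2cn3ccnc3c(-c3ccc4ncn(C5CCCCC5)c4c3)n2)cc1` bears hydrogen there and gives 1.74 in a physicochemical assay for lipophilicity, using the shake flask method, in phosphate buffer, measured as octanol-water partition, with a stated time of 85 min, at pH 7.4; on this read-out higher numbers stand for higher lipophilicity and lower numbers for lower lipophilicity. Compound 2 `Fc1ccc(-c2cn3ccnc3c(-c3ccc4ncn(C5CCCCC5)c4c3)n2)cc1` carries fluoro and gives 2.01 in this assay. Compound 3 `CCc1ccc(-c2cn3ccnc3c(-c3ccc4ncn(C5CCCCC5)c4c3)n2)cc1` carries ethyl and gives 1.66 in this assay. Among the compounds with values here, on these numbers compound 3 sits with compound 1 within the scatter, as the step of a number 0.08 log units lower from compound 1 to compound 3 (within the scatter) shows, and only the step of a number 0.35 log units lower from compound 2 to compound 3 (beyond the scatter) separates it from a neighbour beyond the scatter.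

The next compound, compound 4 `Clc1ccc(-c2cn3ccnc3c(-c3ccc4ncn(C5CCCCC5)c4c3)n2)cc1`, differs from compound 3 by chloro in place of ethyl on an aromatic carbon. Within the data shown here, two measured steps bear on this exchange. The step of a number 0.35 log units lower from compound 2 to compound 3 (beyond the scatter) compares ethyl with a halogen at the same position, and the step of a number 0.27 log units higher from compound 1 to compound 2 (within the scatter) shows what that halogen did against hydrogen, while a number 0.08 log units lower from compound 1 to compound 3 (within the scatter) places ethyl against hydrogen. Among the measured compounds shown here, no measured pair carries chloro. Reading chloro alongside fluoro, reversing the ethyl-for-halogen step and adding a margin, a modest rise in this assay from compound 3 to compound 4 is expected, estimated as a number 0.49 log units higher from compound 3 to compound 4 (beyond the scatter). Compound 4 is therefore expected to give about 2.15 in this assay, with a range from 1.85 to 2.45.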

Compound 4, partition coefficient: 1.51
Compound 4: middle estimate off by 0.64 log units, on the high side; the measured number lies below the stated range.
By their numbers in this assay, from the lowest: compounds 4, 3, 1 and 2 (each within the scatter of the next, the first and the last beyond it).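

In this assay the exchange of 4-ethylphenyl to 4-chlorophenyl, on an aromatic carbon para to a large group, gives a number 0.15 log units lower from compound 3 to compound 4 (within the scatter) and the exchange of hydrogen for chloro gives a number 0.23 log units lower from compound 1 to compound 4 (within the scatter) so chloro cannot be told apart from either ethyl or hydrogen at this position. The earlier compounds shown here held no chloro, and the new comparison between the two halogens shows a separation: a number 0.50 log units lower from compound 2 to compound 4 (beyond the scatter) so fluoro and chloro do not read alike here, although fluoro itself stays within the scatter of hydrogen and only chloro and ethyl lie beyond it from fluoro. No measurement at hand bears on why the two halogens part at this position.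

Going by these compounds, whether bromo would read with chloro or with fluoro remains open, so the separation between the halogens rests on a single pair. Also open, on these data alone, is whether an amine, a carboxylic acid or a longer chain at the same position would move the partition coefficient well beyond the narrow band held by hydrogen, ethyl and chloro on the shared core.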